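The source may report more compounds than this note shows. Statements on the series, on what has been measured and on what is new or still open speak of the compounds shown alone.

Of the compounds shown here, three with a shared core have been tested in a functional assay on HUVEC cells (Homo sapiens) for antiproliferative activity, read by MTT assay, with a stated time of 24 h; on this read-out higher numbers stand for weaker inhibition and lower numbers for stronger inhibition. Compound 1 `C#CCOc1ccc2c(=O)c(-c3cc(OC)c(OC)cc3OC)coc2c1`, with a propargyl group on an oxygen on an aromatic ring, reads > 10000 nM, which is a limit of the assay and not a number. Compound 2 `COc1cccc(C(=O)Oc2ccc3c(=O)c(-c4cc(OC)c(OC)cc4OC)coc3c2)c1`, with (3-methoxyphenyl)carbonyl in that place, reads > 10000 nM, also a limit. Among the measured compounds shown here, compound 3 `COc1cc(OC)c(-c2coc3cc(OCc4ccccc4F)ccc3c2=O)cc1OC`, with 2-fluorobenzyl there, gives 4300 nM, the only actual number so far.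

Compound 4 `COc1cc(OC)c(-c2coc3cc(OCc4ccc(C#N)cc4)ccc3c2=O)cc1OC` has 4-cyanophenyl in place of 2-fluorophenyl on a saturated chain carbon bound to an oxygen on an aromatic ring.

Two measured steps lead to compound 3: an at least 2.3-fold lower number from compound 1 to compound 3 (0.36 log units; beyond the scatter) and an at least 2.3-fold lower number from compound 2 to compound 3 (0.36 log units; beyond the scatter). Each replaces the whole group on the oxygen, and neither tests a change on the phenyl ring, so they offer only weak guidance here. No step beyond the scatter is therefore expected in this assay. The estimated step is a 1.2-fold higher number from compound 3 to compound 4 (0.07 log units; within the scatter). For compound 4 the expected value is 5000 nM, with an estimated range from 1700 nM to 10000 nM.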

Compound 4, half-maximal inhibitory concentration: > 10000 nM
Compound 4: a limit, no number (the forecaster's own chance of this, stated with the estimate: 30%); middle value at least 2.0-fold (0.30 log units) away from the limit.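

In this assay, the first change shown on the phenyl ring itself, 4-cyanophenyl in place of 2-fluorophenyl, brings an at least 2.3-fold higher number from compound 3 to compound 4 (0.36 log units; beyond the scatter), so the earlier swaps of the whole group on the oxygen gave no sign that this ring could matter on its own. On these data alone, compound 4 gives > 10000 nM, which is a limit of the assay and not a number, so the real size of this step stays unknown. The steps to compound 4 from compound 1 and compound 2 cannot be read, and the comparisons here are few: the limit of > 10000 nM in this assay, at which 3 of the 4 values shown sit.

The swap changes both the substituent and its printed ring number, so the compounds shown cannot separate those two changes. A 4-fluorobenzyl or 2-cyanobenzyl group would pull them apart, while 2-aminobenzyl would show how an amine behaves at this place.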